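From a Tetrazolyl Group to Carboxymethyl at the Chain End

The source may hold more compounds than are shown below. What is called first, only, known or untested is meant among the compounds shown, and "the series" means these compounds.

Measured so far:
compound 1, `CCc1cc(C(C)=O)c(O)cc1OCCCCC#N`: 57%
compound 2, `CCc1cc(C(C)=O)c(O)cc1OCCCCCC(C)(C)c1nnnn1C`: 59%

In an assay on isolated protein for binding affinity to leukotriene B4 receptor 1 (Homo sapiens), tested at 1 uM (on this read-out lower numbers stand for less inhibition and higher numbers for more inhibition at the one concentration tested (going by the name of the read-out)), compound 2 gives 59%, the higher of the two numbers recorded, while compound 1 gives 57%, a value that lies within the usual scatter of compound 2, so the two cannot be ordered. Within the data shown here, no step between measured compounds is available. Compound 3, `CCc1cc(C(C)=O)c(O)cc1OCCCCCCC(=O)O`, differs from compound 2 as follows: carboxymethyl in place of 1-methyl-1-(1-methyl-1H-tetrazol-5-yl)ethyl on a saturated chain carbon, five bonds along the chain from an oxygen on an aromatic ring. With only the two measured compounds as a guide, the step from compound 2 to compound 3 is expected to stay within the scatter, a number 4 percentage points higher from compound 2 to compound 3 (within the scatter). Compound 3 is therefore estimated at 63%, with a range from 40% to 85%.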

Compound 3, a percentage reported as inhibition, at one concentration (the size of the read-out at that concentration, not a potency): 38%
Compound 3: middle estimate off by 25 percentage points, on the high side, outside the stated range (below it).
By their numbers in this assay, from the lowest: compound 3; then compounds 1 and 2 (each within the scatter of the next).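

Carboxymethyl in place of 1-methyl-1-(1-methyl-1H-tetrazol-5-yl)ethyl gives a number 21 percentage points lower from compound 2 to compound 3 (beyond the scatter) in this assay and 2-carboxyethyl in place of cyano gives a number 19 percentage points lower from compound 1 to compound 3 (beyond the scatter) on the same saturated chain. The chain end therefore does matter here, since the nitrile of compound 1 and the tetrazolyl group of compound 2 had not separated from each other, whereas the carboxylic acid of compound 3 does separate from both. Nothing measured here accounts for this difference. Going by these compounds, whether a methyl ester, a primary amide or an amine at the chain end would stay with compound 1 and compound 2 remains open. So does the effect of a longer chain carrying the carboxylic acid.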